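Dimethylaminopropyl ether on the dibromophenol of compound 2

The source may hold more compounds than are shown below. What is called first, only, known or untested is meant among the compounds shown, and "the series" means these compounds.

Measured compounds:
compound 1 `CNCCCOc1c(Br)cc(-c2c[nH]c(=O)c(Cc3ccc(OC)c(Br)c3)n2)cc1Br`: 10300 nM
compound 2 `COc1ccc(Cc2nc(-c3cc(Br)c(O)c(Br)c3)c[nH]c2=O)cc1Br`: "not determined" (no result reported)
compound 3 `COc1ccc(Cc2nc(-c3cc(Br)c(O)c(Br)c3)cnc2Cl)cc1Br`: "not determined" (no result reported)

In a functional assay on COLO 205 cells (Homo sapiens) for inhibition, read by MTT assay, with a stated time of 24 h (on this read-out higher numbers stand for weaker inhibition and lower numbers for stronger inhibition), compound 1 gives 10300 nM. Compound 2 has no number in this assay; its entry reads "not determined" (no result reported). Compound 3 likewise carries no number, its entry being "not determined" (no result reported). Within the data shown here, compound 2 therefore cannot be placed against any measured value here; the only number belongs to compound 1.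

Compound 4 `COc1ccc(Cc2nc(-c3cc(Br)c(OCCCN(C)C)c(Br)c3)c[nH]c2=O)cc1Br` is the next compound to be measured. Its difference from compound 2:
3-(dimethylamino)propyl in place of hydrogen on an oxygen on an aromatic ring

Among the measured compounds shown here, no step between measured compounds exists, so the size and direction of the change in this assay from compound 2 to compound 4 cannot be read from the series. For the measured compounds named here, the only guide is compound 1, which carries a related basic chain on the same kind of oxygen and gives 10300 nM. The step is expected to stay near that level, with no clear direction beyond the scatter.

Compound 4 is estimated to give 10000 nM in this assay, within a range from 3000 nM to 35000 nM.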

Compound 4, half-maximal inhibitory concentration: 7900 nM
For compound 4 the middle estimate is 1.3-fold (0.10 log units) above the measured one, within the range that was stated.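

In this assay methyl in place of hydrogen on the amine nitrogen of the basic chain gives a 1.3-fold lower number from compound 1 to compound 4 (0.12 log units; within the scatter) and so leaves the reading at this nitrogen unresolved: the two chain ends cannot be told apart on these values. From the compounds shown here alone, compound 2 carries no number, so the step from hydroxy to 3-(dimethylamino)propoxy cannot be read, and the effect of the chain itself stays unknown. No measurement shown here offers an explanation for this result.

Open questions remain at the oxygen on the aromatic ring, where a longer chain, a primary amine or a carboxylic acid in place of 3-(dimethylamino)propyl could be compared with compound 4 in this assay on the same core. A reading for a compound with the free hydroxy is also needed to anchor the series.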